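This account rests on a few compounds, and the source may have more. Where it says the series, first, only, none or still open, it means among the compounds named here.

Measured in a functional assay on MDA-MB-231 cells (Homo sapiens) for inhibition, read by MTT assay, with a stated time of 48 h; a lower number here means a stronger inhibitor, a higher number a weaker inhibitor:
- compound 1 `C[Se]c1ccc(N(C)c2nc(C3CC3)nc3ccccc23)cc1`: 18 nM
- compound 2 `COc1ccc(N(C)c2nc(C)nc3ccccc23)cc1C(=O)NCC[Se]C#N`: 1250 nM
- compound 3 `Cc1nc(N(C)c2ccc(OCC[Se]C#N)cc2)c2ccccc2n1`: 317 nM

Compound 2 has the highest number of the three, and both other compounds lie lower, beyond the scatter, so it is the weakest inhibitor so far. Compound 4 `COc1ccc(N(C)c2nc(C)nc3ccccc23)cc1C[Se]C#N` departs from compound 2 in one place: a group of 4 heavy atoms (2 carbon, 1 nitrogen, 1 selenium; no ring) in place of a group of 8 heavy atoms (4 carbon, 2 nitrogen, 1 oxygen, 1 selenium; no ring), on an aromatic carbon. Going by the values given here, no measured pair isolates this change, so the expectation is only loosely anchored. Compound 2 carries a carbonyl that compound 3 lacks, and compound 3 gives 317 nM, which points to a lower number. The expected change in this assay is a moderate one toward stronger inhibition, a 3.1-fold lower number from compound 2 to compound 4 (0.49 log units; beyond the scatter). For compound 4 the estimated value is 400 nM, with an expected range of 100 nM to 1500 nM.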

Compound 4, half-maximal inhibitory concentration: 153 nM
Compound 4: middle estimate off by 2.6-fold (0.42 log units), on the high side; the measured number falls inside the stated range.
By their numbers in this assay, from the lowest: compound 1; then compound 4; then compound 3; then compound 2.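

In this assay, going by these compounds alone, the change gives an 8.2-fold lower number from compound 2 to compound 4 (0.91 log units; beyond the scatter), the first one-place comparison. At this position, ortho to a methoxy group, the smaller group without the carbonyl and the amide hydrogen goes with stronger inhibition. No available data explain the step.

The carbonyl and the chain length change together here, so their contributions remain unseparated. A longer carbon chain or an amine linker at this position, ending in the same selenium-nitrile unit, would bear on that question.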